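Methoxy for Cyano on a Coumarin-Triazole Series

The source may hold more compounds than are shown below. What is called first, only, known or untested is meant among the compounds shown, and "the series" means these compounds.

Going by the values given here, compound 2 `N#Cc1ccccc1-n1cc(COc2ccc3oc(=O)ccc3c2)nn1` is the only member of this set with a number: in a functional assay on A549 cells (Homo sapiens) for cytotoxicity, read by MTT assay, with a stated time of 48 h (on this read-out lower numbers stand for stronger inhibition and higher numbers for weaker inhibition), compound 2 gives 12600 nM. Compound 1 `O=c1ccc2cc(OCc3cn(-c4ccccc4)nn3)ccc2o1` has in this assay only the entry "not determined" (no result reported). Compound 3 `COc1ccccc1-n1cc(COc2ccc3oc(=O)ccc3c2)nn1` is not yet measured; it differs from compound 2 by methoxy in place of cyano on an aromatic carbon. Among the compounds with values here, no measured pair shows this change, so the step from compound 2 to compound 3 in this assay is expected to stay within the usual scatter, with no clear direction. Compound 3 is therefore estimated at 14000 nM, between 5000 nM and 40000 nM, an expected step of a 1.1-fold higher number from compound 2 to compound 3 (0.05 log units; within the scatter).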

Compound 3, half-maximal inhibitory concentration: 18700 nM
The estimate for compound 3 lay 1.3-fold (0.13 log units) below the measured number; low and high end bracket the measured number.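

In this assay, going by these compounds alone, the change from cyano to methoxy on this aromatic carbon, ortho to a large group, gives a 1.5-fold higher number from compound 2 to compound 3 (0.17 log units; within the scatter), the first measured step in the set. At this position, the 2-cyanophenyl and 2-methoxyphenyl compounds therefore cannot be told apart. Nothing available bears on why the two groups read alike. The compounds shown leave open whether an amine or a carboxylic acid at this position would give a step beyond the scatter. They also leave open what a longer chain, such as butoxy, would do there.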